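This account rests on a few compounds, and the source may have more. Where it says the series, first, only, none or still open, it means among the compounds named here.

In a functional assay on SK-BR-3 cells (Homo sapiens) for antiproliferative activity (a lower number here means that less compound is needed, a higher number that more compound is needed for the effect), compound 1 `CCOC(=O)C(=O)Nc1ccc2nc(NC(=O)c3cc4cc(C)ccc4[nH]3)sc2c1` gives 2810 nM. Compound 2 `CCOC(=O)C(=O)Nc1ccc2nc(NC(=O)c3ncccn3)sc2c1` is reported as > 50000 nM. As far as these compounds go, that entry is a limit of the assay and not a number, so the true position of compound 2 remains unknown.

Compound 3 `CCOC(=O)C(=O)Nc1ccc2nc(NC(=O)c3ccc(OC)cc3)sc2c1` keeps the shared core and changes one group: 4-methoxyphenyl in place of pyrimidin-2-yl on a carbonyl carbon. In words, 4-methoxyphenyl takes the place of pyrimidin-2-yl on a carbonyl carbon.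

Among the compounds with values here, one measured step bears on this same place: an at least 17-fold higher number from compound 1 to compound 2 (1.25 log units; beyond the scatter). This step is large and beyond the scatter, so the group on this carbonyl carbon can clearly matter in this assay. Within the data shown here, the new group differs from the one in compound 1 at 2810 nM, so only part of that step is expected to be recovered.

A moderate move to a lower number is expected, and the estimated step is an at least 3.3-fold lower number from compound 2 to compound 3 (0.52 log units; beyond the scatter). For compound 3 the expected value is 15000 nM, with an estimated range of 4000 nM to 50000 nM.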

Compound 3, half-maximal effective concentration: 10700 nM
For compound 3 the middle estimate is 1.4-fold (0.15 log units) above the measured one, within the range that was stated.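

In this assay, within the data shown here, replacing pyrimidin-2-yl with 4-methoxyphenyl gives an at least 4.6-fold lower number from compound 2 to compound 3 (0.66 log units; beyond the scatter), so the 5-methyl-1H-indol-2-yl group of compound 1 is not the only group on this carbonyl carbon that gives a measurable value. Still, 4-methoxyphenyl does not match that group: exchanging one for the other gives a 3.8-fold higher number from compound 1 to compound 3 (0.58 log units; beyond the scatter), which places compound 3 in the middle of the three compounds. Compound 2 is reported at a limit and not a number, so the first step can only be stated as a minimum because of this entry: the limit of > 50000 nM in this assay, at which 1 of the 3 values shown sits.

The three groups differ in several ways at once, so these compounds cannot show which difference matters. As far as these compounds go, it also stays open whether a phenyl ring carrying an amine or a carboxylic acid instead of methoxy would come closer to compound 1.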